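This account rests on a few compounds, and the source may have more. Where it says the series, first, only, none or still open, it means among the compounds named here.

Compound 1 `CC(C)N1CCN(Cc2csc(N)c2C(=O)c2ccc(Cl)cc2)CC1` gives 7.3% in a functional assay on CHO cells with adenosine receptor A1 (Homo sapiens) as the target, read by cAMP accumulation and immunoassay, with a stated time of 6 min, tested at 1 uM; a lower number here means a stronger effect, a higher number a weaker effect of the compound at the concentration tested.
Compound 2 `Nc1scc(CN2CCN(c3cccc(Cl)c3Cl)CC2)c1C(=O)c1ccc(Cl)cc1` gives -57% in this assay.
Compound 3 `Nc1scc(CN2CCN(c3cc(Cl)cc(Cl)c3)CC2)c1C(=O)c1ccc(Cl)cc1` gives -69% in this assay.

Compound 3 stands lowest of the three numbers in this assay: compound 2 sits nearest, and compound 1 furthest, with both steps beyond the scatter. Compound 4 `Nc1scc(CN2CCN(c3ccc(F)cc3Cl)CC2)c1C(=O)c1ccc(Cl)cc1` has not been measured in this assay. It differs from compound 3 as follows: 2-chloro-4-fluorophenyl in place of 3,5-dichlorophenyl on an amine nitrogen in a ring.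

Two kinds of step bear on this change. Replacing isopropyl with a dichlorophenyl produced the large steps of a number 64.3 percentage points lower from compound 1 to compound 2 (beyond the scatter) and a number 76.3 percentage points lower from compound 1 to compound 3 (beyond the scatter). Exchanging one dichlorophenyl for another produced only the modest step of a number 12 percentage points lower from compound 2 to compound 3 (beyond the scatter). Compound 4 keeps an aryl group bearing two halogens on the same ring nitrogen, so the step from compound 3 is expected to resemble the aryl-for-aryl exchange rather than the alkyl-for-aryl one, and is estimated as a number 9 percentage points higher from compound 3 to compound 4 (within the scatter), a change that would not clearly exceed the scatter. Compound 4 is therefore expected to give about -60% in this assay, within a range from -82% to -38%.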

Compound 4, a percentage reported as activity, at one concentration (the size of the read-out at that concentration, not a potency): -39%
The estimate for compound 4 lay 21 percentage points below the measured number; measured number inside the range.
By their numbers in this assay, from the lowest: compound 3; then compound 2; then compound 4; then compound 1.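

The aryl-for-aryl exchange on this ring nitrogen is not always a small change in this assay: a number 30 percentage points higher from compound 3 to compound 4 (beyond the scatter) is a larger move than the earlier a number 12 percentage points lower from compound 2 to compound 3 (beyond the scatter), and a number 18 percentage points higher from compound 2 to compound 4 (beyond the scatter) is also beyond the scatter. The 2-chloro-4-fluorophenyl group still stays well apart from isopropyl, with a number 46.3 percentage points lower from compound 1 to compound 4 (beyond the scatter), so all three halogenated phenyl groups shown give lower numbers than isopropyl, and no compound here goes against this. Nothing available accounts for the differences among these phenyl groups.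

Compound 4 differs from compound 2 and compound 3 in both the kind of halogen and where the halogens sit, and the compounds shown do not separate these two changes. They also leave open how an unsubstituted phenyl, a methoxyphenyl or a pyridyl group on the same nitrogen would read.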